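Methyl on the piperidine ring of a kinase-type inhibitor series

The compounds below may be only part of what the source reports. "The series", "measured", "known", "first", "only" and "open" are said of these compounds alone.

Measured compounds:
Compound 1, `COc1cc2c(Oc3ccc(NC(=O)c4nn(-c5ccccc5C)c(=O)cc4C)cc3F)ccnc2cc1OCCCN1CCC(C)CC1`: 2810 nM
Compound 2, `COc1cc2c(Oc3ccc(NC(=O)c4nn(-c5ccccc5C(F)(F)F)c(=O)cc4C)cc3F)ccnc2cc1OCCCN1CCCC1`: 140 nM
Compound 3, `COc1cc2c(Oc3ccc(NC(=O)c4nn(-c5ccccc5C(F)(F)F)c(=O)cc4C)cc3F)ccnc2cc1OCCCN1CCCCC1`: 170 nM

Of the compounds shown here, three share one core and have been tested in a functional assay on HT-29 cells (Homo sapiens) for inhibition, read by MTT assay, with a stated time of 72 h; on this read-out lower numbers stand for stronger inhibition and higher numbers for weaker inhibition. Compound 3 stands second highest of the three numbers; compound 2 is nearest to it, and compound 1 lies furthest away. For the measured compounds named here, the change from compound 2 to compound 3 is the only single-point step among the measured compounds, and it gave a 1.2-fold higher number from compound 2 to compound 3 (0.08 log units; within the scatter), so the size of the amine ring at the end of the chain made no difference that rises above the scatter.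

Compound 4, `COc1cc2c(Oc3ccc(NC(=O)c4nn(-c5ccccc5C(F)(F)F)c(=O)cc4C)cc3F)ccnc2cc1OCCCN1CCC(C)CC1`, is not yet measured. It arises from compound 3 by methyl in place of hydrogen on a saturated ring carbon. Compound 1 also carries a 4-methylpiperidin-1-yl group, but it differs from compound 4 elsewhere as well; the value of compound 1, 2810 nM, therefore says little about this step on its own. Going by the values given here, the only closely related step, from compound 2 to compound 3, was within the scatter; the expected step for compound 4 is therefore a 1.2-fold higher number from compound 3 to compound 4 (0.07 log units; within the scatter), that is none beyond the scatter. Compound 4 is expected to give about 200 nM in this assay, estimated between 80 nM and 600 nM.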

Compound 4, half-maximal inhibitory concentration: 180 nM
Estimate against measurement, compound 4: 1.1-fold (0.05 log units) above; the range from low to high includes it.
By their numbers in this assay, from the lowest: compounds 2, 3 and 4 (each within the scatter of the next); then compound 1.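

In this assay, methyl in place of hydrogen on the saturated ring carbon three ring bonds from the ring nitrogen gave a 1.1-fold higher number from compound 3 to compound 4 (0.02 log units; within the scatter) and so stayed within the scatter, which shows that this position tolerates the added carbon. Replacing pyrrolidin-1-yl with 4-methylpiperidin-1-yl gave a 1.3-fold higher number from compound 2 to compound 4 (0.11 log units; within the scatter) and also stayed within the scatter, so none of the three amine rings carrying the trifluoromethyl group stands apart. Compound 4 also isolates the aromatic change, since trifluoromethyl in place of methyl gave a 16-fold lower number from compound 1 to compound 4 (1.19 log units; beyond the scatter) with the 4-methylpiperidin-1-yl group held constant, so that group alone does not account for the high number of compound 1.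

Still open, on these data alone, is whether a morpholine, a 4-methylpiperazine or a longer chain before the amine would also stay within the scatter. Nothing measured here explains these results.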